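The source may hold more compounds than are shown below. What is called first, only, known or untested is meant among the compounds shown, and "the series" means these compounds.

Compound 1 `CCOC(=O)[C@H](CCC(=O)O)NC(=O)c1ccc(CNc2nc3cc(N)cc(N)c3nc2-c2ccccc2)cc1` gives a limit of < 100000 nM in a functional assay on NCI-H226 cells (Homo sapiens) for inhibition, read by sulforhodamine B assay, with a stated time of 48 h; on this read-out lower numbers stand for stronger inhibition of growth and higher numbers for weaker inhibition of growth. Compound 2 `Nc1cc(N)c2nc(-c3ccccc3)c(NCc3ccc(Cl)c(Cl)c3)nc2c1` gives 46800 nM in this assay . Compound 3 `COc1ccc(CNc2nc3cc(N)cc(N)c3nc2-c2ccccc2)cc1OC` gives 30900 nM in this assay .

Compound 3 holds the lowest of the two numbers shown, with compound 2 nearest to it, and the step of a 1.5-fold lower number from compound 2 to compound 3 (0.18 log units; within the scatter) lies within the scatter, so no order between the two can be claimed. The value for compound 1 is a limit and not a number, as stated in the limit of < 100000 nM in this assay, at which 1 of the 3 values shown sits. Compound 4 `COc1cc(CNc2nc3cc(N)cc(N)c3nc2-c2ccccc2)cc(OC)c1OC` differs from compound 3 by methoxy in place of hydrogen on an aromatic carbon. Among the measured compounds shown here, only the step from compound 2 to compound 3 bears on this change, since it also reworked the substituents on the same aromatic ring, and that whole exchange of 3,4-dichlorophenyl for 3,4-dimethoxyphenyl stayed within the scatter. Adding one further methoxy group is a smaller change than that exchange, so the step in this assay from compound 3 to compound 4 is expected to be a 1.0-fold lower number from compound 3 to compound 4 (0.01 log units; within the scatter), no larger than the scatter. Compound 4 is therefore estimated at 30000 nM in this assay , with a range from 10000 nM to 90000 nM.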

Compound 4, concentration for total growth inhibition: 22400 nM
For compound 4 the middle estimate is 1.3-fold (0.13 log units) above the measured one, and the stated range covers the measured number.
By their numbers in this assay, from the lowest: compounds 4, 3 and 2 (each within the scatter of the next, the first and the last beyond it).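

In this assay, adding methoxy at this aromatic carbon, ortho to a methoxy group and meta to a large group, gives a 1.4-fold lower number from compound 3 to compound 4 (0.14 log units; within the scatter). The earlier step exchanged the substituents on this ring together, whereas this one changes a single place with the rest of compound 3 held constant, so the position accepts a methoxy group with no change that can be told from the scatter. Nothing shown bears on the reason for the size of this step.

Going by these compounds, whether an amine, a carboxylic acid or a hydroxy group at this same carbon would move the number beyond the scatter remains open. On these data alone, it is also open whether a longer chain in place of methoxy, such as ethoxy, would do so.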